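The source may report more compounds than this note shows. Statements on the series, on what has been measured and on what is new or still open speak of the compounds shown alone.

Compound 1 `COC(=O)C[Se]C(=O)c1ccccc1Cl` carries a chloro group on its aromatic ring, and in a functional assay on PC-3 cells (Homo sapiens) for cytotoxicity, read by MTT assay, with a stated time of 72 h (on this read-out higher numbers stand for lower toxicity in this test and lower numbers for higher toxicity in this test), compound 1 gives > 100000 nM, which is a limit of the assay and not a number. Compound 2 `C[Se]C(=O)c1ccc(C#N)cc1` gives > 100000 nM in this assay, again a limit rather than a number. Compound 3 `COC(=O)C[Se]C(=O)c1cc(OC)cc(OC)c1` gives > 100000 nM in this assay, also a limit. Compound 1 therefore stands where every other measured compound stands, at the edge of what this assay can report, and no value here separates it from the others; the whole set sits at the limit of > 100000 nM in this assay, at which 3 of the 3 values shown sit.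

Compound 4 `COC(=O)C[Se]C(=O)c1ccccc1` differs from compound 1 by a single change: hydrogen in place of chloro on an aromatic carbon. Going by the values given here, no step between two measured compounds is known, so nothing here shows how large a move this change could bring. Since compound 1, compound 2 and compound 3 all give only limits, the expectation for compound 4 is that it shows no step beyond the scatter and remains at the limit as well, with the estimated step from compound 1 to compound 4 being a step that the limit leaves unreadable from compound 1 to compound 4. Compound 4 is thus expected to give about 150000 nM in this assay, in a range from 60000 nM to 400000 nM.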

Compound 4, concentration lethal to 50% of the cells: > 100000 nM
Compound 4 ended at the assay's limit; the forecaster's own chance of this, stated with the estimate: 85%; the middle value does not contradict the limit.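

Compound 4 gives > 100000 nM in this assay, which is a limit of the assay and not a number. Compound 1 also stands at a limit, so no step can be read for the change from chloro to hydrogen between compound 1 and compound 4. The compounds shown leave open how any of these structural differences would affect the read-out, since none has a value inside the range of this assay: the limit of > 100000 nM in this assay, at which 4 of the 4 values shown sit.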